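Cyclohexyl for methyl on an aromatic nitrogen: tolerance

The source may report more compounds than this note shows. Statements on the series, on what has been measured and on what is new or still open speak of the compounds shown alone.

Compound 2 `CC(=O)Nc1ccc(-c2nc3cc(C(F)(F)F)ccc3n2C)cc1` in an ADME assay on BHK cells (Mesocricetus auratus) for cytotoxicity, read by MTT assay, with a stated time of 96 h (a higher number here means that more compound is tolerated, a lower number that less compound is tolerated), gives only a limit, > 100000 nM. Compound 3 `CCC(=O)Nc1ccc(-c2nc3cc(C(F)(F)F)ccc3n2C)cc1` also reaches a limit in this assay, > 100000 nM. This is the limit of > 100000 nM in this assay, at which 2 of the 3 values shown sit. Compound 1 `CCC(=O)Nc1ccc(-c2nc3cc(C(F)(F)F)ccc3n2C2CCCCC2)cc1` in this assay gives 15000 nM. Among the compounds with values here, the only readable step, an at least 6.6-fold higher number from compound 1 to compound 3 (0.82 log units; beyond the scatter), is the same change run in the opposite direction to the one considered here, and the step that the two limits leave unreadable from compound 2 to compound 3 adds nothing. Compound 4 `CC(=O)Nc1ccc(-c2nc3cc(C(F)(F)F)ccc3n2C2CCCCC2)cc1` differs from compound 2 by cyclohexyl in place of methyl on an aromatic nitrogen. Mirroring the measured step, the expected step of an at least 6.6-fold lower number from compound 2 to compound 4 (0.82 log units; beyond the scatter) is a drop of at least modest size. Compound 4 is therefore expected to give about 15000 nM in this assay, within 5000 nM to 60000 nM.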

Compound 4, half-maximal cytotoxic concentration: 15000 nM
Estimate against measurement, compound 4: no gap at the digits printed; the range from low to high includes it.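

With the shorter amide chain, cyclohexyl in place of methyl on the aromatic nitrogen also costs tolerance in this assay, with an at least 6.6-fold lower number from compound 2 to compound 4 (0.82 log units; beyond the scatter). Hydrogen in place of methyl on the saturated chain carbon bound to the carbonyl carbon becomes readable for the first time, on the cyclohexyl compounds, with no change at the digits printed from compound 1 to compound 4 (within the scatter). The nitrogen change therefore reads alike on both cores: the same change on two cores in this assay, an at least 6.6-fold higher number (0.82 log units; beyond the scatter) from compound 1 to compound 3 and an at least 6.6-fold higher number (0.82 log units; beyond the scatter) from compound 4 to compound 2; the limit leaves it open whether they differ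

The steps that rest on limits give only a minimum, and the step between the two methyl compounds cannot be read. As far as these compounds go, whether ethyl or cyclopropyl on the aromatic nitrogen keeps a compound at the limit remains open.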